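A few compounds are considered here, and "the series" means these few. Any claim that something is new, unique, unknown or untested is made for them only; others in the source may bear on it.

Going by the values given here, compound 2 `O=C(/C=C/c1ccc2c(c1)B(O)OC2)c1ccc(F)cc1` gives the lower of the two numbers so far seen in a functional assay on MDA-MB-231 cells (Homo sapiens) for cytotoxicity, read by MTT assay, with a stated time of 48 h (a higher number here means a weaker inhibitor, a lower number a stronger inhibitor), namely 1600 nM. Among the compounds with values here, its only comparator, compound 1 `O=C(/C=C/c1ccc2c(c1)B(O)OC2)c1ccc(-c2ccccc2)cc1`, gives 6400 nM in this assay, and the single measured step, a 4.0-fold lower number from compound 1 to compound 2 (0.60 log units; beyond the scatter), separates the pair. Compound 3 `O=C(/C=C/c1ccc2c(c1)B(O)OC2)c1ccccc1O` awaits measurement in this assay. 2-hydroxyphenyl in place of 4-fluorophenyl on a carbonyl carbon The step from compound 1 to compound 2 altered the same aryl group on the carbonyl carbon, yet it put a fluoro in place of a phenyl rather than a 2-hydroxyphenyl in place of a 4-fluorophenyl, so it bears on the present change only by showing that this part of the molecule shifts the number by a modest amount. Within the data shown here, no measured pair shows what a hydroxyl entering this ring does. On such thin evidence the expected step in this assay is small, with no clear direction. Compound 3 is therefore estimated at 2500 nM in this assay, within a range of 900 nM to 7000 nM. Compound 3 is thus expected to show a 1.6-fold higher number from compound 2 to compound 3 (0.19 log units; within the scatter).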

Compound 3, half-maximal inhibitory concentration: 16900 nM
Estimate against measurement, compound 3: 6.8-fold (0.83 log units) below; the measured number lies above the stated range.
By their numbers in this assay, from the lowest: compound 2; then compound 1; then compound 3.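

In this assay the aryl group on the carbonyl carbon turns out to move the number much further than the earlier pair suggested: an 11-fold higher number from compound 2 to compound 3 (1.02 log units; beyond the scatter) is a large step, against the modest 4.0-fold lower number from compound 1 to compound 2 (0.60 log units; beyond the scatter) seen before, and compound 3 at 16900 nM also stands above compound 1 at 6400 nM in the printed values. The change is not one of heavy-atom count, since 2-hydroxyphenyl and 4-fluorophenyl match on that count and each carries one six-membered aromatic ring of carbon only; what differs is that fluorine gives way to oxygen and the entering group counts a hydrogen-bond donor and acceptor that the leaving group lacks. No measurement among the data accounts for the size or direction of this step.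

The compounds shown leave open whether the higher number follows from the hydroxyl itself, from the loss of the fluoro, or from where the substituent sits on the ring, as all three change together in this one step. On these data alone, a 4-hydroxyphenyl or a 2-fluorophenyl would pull these apart, and how a 2-methoxyphenyl or a 2-aminophenyl on the same carbonyl carbon would read remains unknown from these compounds.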